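Two Weak Inhibitors and an Untested Oxygen-Linked Pyrimidine

A few compounds are considered here, and "the series" means these few. Any claim that something is new, unique, unknown or untested is made for them only; others in the source may bear on it.

Compound 1, `CC(C)[C@H](NC(=O)COc1cccc2ccccc12)C(=O)N[C@@H](CC(=O)O)C(=O)CSc1nnnn1-c1ccccc1`, gives 153000 nM.
Compound 2, `CC(C)[C@H](NC(=O)COc1cccc2ccccc12)C(=O)N[C@@H](CC(=O)O)C(=O)CSc1nc2ccccc2[nH]1`, gives > 200000 nM.

In a functional assay on Jurkat cells (Homo sapiens) for inhibition (on this read-out lower numbers stand for stronger inhibition and higher numbers for weaker inhibition), compound 1 gives 153000 nM, a very weak result. For compound 2 the read-out is only a limit of the assay, > 200000 nM, and it is not a measured number; this is the limit of > 200000 nM in this assay, at which 1 of the 2 values shown sits. For the measured compounds named here, the one measured step, an at least 1.3-fold higher number from compound 1 to compound 2 (0.11 log units; that floor lies within the scatter), is therefore only a floor, and that floor sits within the usual scatter, so the two compounds cannot be ordered.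

Compound 3, `CC(C)[C@H](NC(=O)COc1cccc2ccccc12)C(=O)N[C@@H](CC(=O)O)C(=O)COc1ccncn1`, differs from compound 2 in one place: (pyrimidin-4-yl)oxy in place of (1H-benzimidazol-2-yl)sulfanyl on a saturated chain carbon bound to a carbonyl carbon. Going by the values given here, no measured step covers this exchange directly. Among the compounds with values here, the only step at hand, an at least 1.3-fold higher number from compound 1 to compound 2 (0.11 log units; that floor lies within the scatter), swaps one ring on the sulfur for another and gives no clear change. Both measured compounds sit at the weak end, and the sulfur itself is now replaced by oxygen together with a different ring, so nothing here points in either direction beyond the scatter.

Compound 3 is therefore expected at about 150000 nM, with a likely range from 30000 nM to 600000 nM. This expectation corresponds to a step of an at least 1.3-fold lower number from compound 2 to compound 3 (0.12 log units; that floor lies within the scatter), which is not expected to exceed the scatter.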

Compound 3, half-maximal inhibitory concentration: > 200000 nM
Compound 3: only a limit was reported (the forecaster's own chance of this, stated with the estimate: 45%); middle value at least 1.3-fold (0.12 log units) from the limit.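

In this assay, compound 3 also gives a limit of the assay and not a number: the limit of > 200000 nM in this assay, at which 2 of the 3 values shown sit.

For the compounds shown here, the one readable step is an at least 1.3-fold higher number from compound 1 to compound 3 (0.11 log units; that floor lies within the scatter), so exchanging the sulfur-linked ring of the first compound for (pyrimidin-4-yl)oxy does not put these two in order. The step between the two limits cannot be read. What is new is that a group linked through oxygen instead of sulfur, on a saturated chain carbon bound to a carbonyl carbon, also stays at the weak end of this read-out, so none of the three groups shown at this place gives a clear change.

The compounds shown leave open whether any other group at this place, such as an amine or a phenoxy group, could bring a clear move to lower numbers. They also leave open how much of the weak read-out belongs to the group at this place and how much to the shared core, which is the same in all three compounds.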